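Ring Size at the Sulfonamide Side Chain and Metabolic Stability

The compounds below may be only part of what the source reports. "The series", "measured", "known", "first", "only" and "open" are said of these compounds alone.

Three compounds sharing one core, with a sulfonamide nitrogen carrying a short saturated chain that ends in a cyclic ether, were tested in an in vitro ADME assay on microsomes from liver (Homo sapiens) for metabolic stability, read by HPLC; a lower number here means slower removal, a higher number faster removal of the compound. Compound 1 `CC1(C)C[C@H](CN([C@H](CCC(F)(F)F)C(N)=O)S(=O)(=O)c2ccc(Cl)cc2)O1` gives 29 mL/min/kg. Compound 2 `NC(=O)[C@@H](CCC(F)(F)F)N(C[C@H]1CCCCO1)S(=O)(=O)c1ccc(Cl)cc1` reaches only a limit of this assay, > 300 mL/min/kg, so no number is known for it. Compound 3 `NC(=O)[C@@H](CCC(F)(F)F)N(C[C@H]1CCCOC1)S(=O)(=O)c1ccc(Cl)cc1` gives 156 mL/min/kg, the highest of the two numbers shown; its nearest neighbour is compound 1, which sits lower by a 5.4-fold higher number from compound 1 to compound 3 (0.73 log units; beyond the scatter). The exchange an at least 10-fold higher number from compound 1 to compound 2 (1.01 log units; beyond the scatter) was large, while the exchange an at least 1.9-fold lower number from compound 2 to compound 3 (0.28 log units; that floor lies within the scatter) is at least a floor that lies within the scatter.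

Compound 4 `NC(=O)[C@@H](CCC(F)(F)F)N(C[C@H]1CCCO1)S(=O)(=O)c1ccc(Cl)cc1` differs from compound 3 by oxolan-2-yl in place of oxan-3-yl on a saturated chain carbon bound to a sulfonamide nitrogen. For the measured compounds named here, the step that bears on it most closely is the one ending at compound 2, whose oxan-2-yl group, also attached through its second ring carbon, ran into the limit (the limit of > 300 mL/min/kg in this assay, at which 1 of the 3 values shown sits). On that basis compound 4 is expected to be cleared faster than compound 3, with the expected step of a 1.6-fold higher number from compound 3 to compound 4 (0.20 log units; within the scatter) being modest and carrying a real chance of again reaching the limit. Compound 4 is therefore estimated at 250 mL/min/kg, within a range from 120 mL/min/kg to 500 mL/min/kg.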

Compound 4, clearance: 231 mL/min/kg
The estimate for compound 4 lay 1.1-fold (0.03 log units) above the measured number; the measured number falls inside the stated range.
By their numbers in this assay, from the lowest: compound 1; then compounds 3 and 4 (each within the scatter of the next). At a limit, above all of these: compound 2.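

In this assay, for the compounds shown here, the change from oxan-3-yl to oxolan-2-yl on a saturated chain carbon bound to a sulfonamide nitrogen gives a 1.5-fold higher number from compound 3 to compound 4 (0.17 log units; within the scatter), so altering ring size and point of attachment together produced no step that stands clear of the scatter. The 4,4-dimethyloxetan-2-yl group of compound 1 still stands apart, with an 8.0-fold higher number from compound 1 to compound 4 (0.90 log units; beyond the scatter), which shows that the oxolan-2-yl ring does not share its low number even though both rings are attached through their second ring carbon. On these data alone, the oxan-2-yl to oxolan-2-yl change rests on a limit and not on a number, so it gives only a floor (an at least 1.2-fold lower number from compound 2 to compound 4 (0.11 log units; that floor lies within the scatter)) and its true size stays unknown: the limit of > 300 mL/min/kg in this assay, at which 1 of the 4 values shown sits.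

Ring size and point of attachment changed together from compound 3 to compound 4, and oxolan-3-yl would be the group that separates them. As far as these compounds go, it also remains open whether the low number of compound 1 goes with its small ring or with its two methyl groups, a question that plain oxetan-2-yl, without those methyl groups, would address.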